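From furan-3-yl to thiophen-2-yl on the shared core

A few compounds are considered here, and "the series" means these few. Any claim that something is new, unique, unknown or untested is made for them only; others in the source may bear on it.

Among the compounds with values here, in an ADME assay on BJ cells (Homo sapiens), read by MTT assay, with a stated time of 72 h (a higher number here means a weaker inhibitor, a lower number a stronger inhibitor), compound 2 `Nc1nc2c(c(-c3ccoc3)cn2[C@@H]2O[C@H](CO)[C@@H](O)[C@H]2O)c(=O)[nH]1` gives 21500 nM as the only exact number so far. Compound 1 `Nc1nc2c(c(-c3ccco3)cn2[C@@H]2O[C@H](CO)[C@@H](O)[C@H]2O)c(=O)[nH]1` reads > 100000 nM as a limit of the assay, not a number. Compound 3 `Nc1nc2c(c(-c3cccs3)cn2[C@@H]2O[C@H](CO)[C@@H](O)[C@H]2O)c(=O)[nH]1` carries thiophen-2-yl in place of furan-3-yl on an aromatic carbon. Within the data shown here, the only guide is the measured swap of furan-2-yl for furan-3-yl (an at least 4.6-fold lower number from compound 1 to compound 2 (0.66 log units; beyond the scatter)), and thiophen-2-yl shares its 2-yl name with the group on compound 1. A modest move towards a higher number, meaning a weaker inhibitor, is therefore expected (a 2.1-fold higher number from compound 2 to compound 3 (0.32 log units; beyond the scatter)). Compound 3 is estimated at 45000 nM (expected range 10000 nM to 100000 nM).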

Compound 3, half-maximal inhibitory concentration: > 100000 nM
Compound 3: no number, only a limit (the forecaster's own chance of this, stated with the estimate: 35%); at least 2.2-fold (0.34 log units) between middle value and limit.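

In this assay, the change to thiophen-2-yl gives an at least 4.6-fold higher number from compound 2 to compound 3 (0.66 log units; beyond the scatter). Two different groups on this aromatic carbon therefore give no exact number, and compound 2, with furan-3-yl, is the only one of the three that does. Compound 1 and compound 3 each read as a limit, not a number, so the step between them cannot be read: the limit of > 100000 nM in this assay, at which 2 of the 3 values shown sit.

Going by these compounds, it remains open whether thiophen-3-yl would give an exact number as furan-3-yl does. Also open, on these data alone, is how an amine or a phenyl ring would read on this carbon.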